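Amine variation on the propoxy chain of the coumarin amide series

The source may report more compounds than this note shows. Statements on the series, on what has been measured and on what is new or still open speak of the compounds shown alone.

compound 1 `CC(C)=CCc1cc(C(=O)Nc2cc3ccc(OCCCN4CCCC4)c(C)c3oc2=O)ccc1O`: 990 nM
compound 2 `CCCN(CCC)CCCOc1ccc2cc(NC(=O)c3ccc(O)c(CC=C(C)C)c3)c(=O)oc2c1C`: > 50000 nM (a limit)
compound 3 `COC(=O)CNCCCOc1ccc2cc(NC(=O)c3ccc(O)c(CC=C(C)C)c3)c(=O)oc2c1C`: 2820 nM

In a functional assay on MCF7 cells (Homo sapiens) for antiproliferative activity (a higher number here means a weaker inhibitor, a lower number a stronger inhibitor), compound 1 gives 990 nM, the lowest of the two numbers shown. Compound 3 is the nearest measured neighbour, a 2.8-fold higher number from compound 1 to compound 3 (0.45 log units; beyond the scatter). For compound 2 the assay reports only a limit, (the limit of > 50000 nM in this assay, at which 1 of the 3 values shown sits). The remaining steps are an at least 50-fold higher number from compound 1 to compound 2 (1.70 log units; beyond the scatter) and an at least 17-fold lower number from compound 2 to compound 3 (1.24 log units; beyond the scatter).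

Compound 4 `CC(C)=CCc1cc(C(=O)Nc2cc3ccc(OCCCNCC(=O)O)c(C)c3oc2=O)ccc1O` is not yet measured. Its difference from compound 1 is (carboxymethyl)amino in place of pyrrolidin-1-yl on a saturated chain carbon, three bonds along the chain from an oxygen on an aromatic ring.

Going by the values given here, the step that bears on it is the one to compound 3, where the ((methoxycarbonyl)methyl)amino group occupies the same chain carbon and gave a 2.8-fold higher number from compound 1 to compound 3 (0.45 log units; beyond the scatter). The step to compound 2 shows that a change at this carbon can also be large, so the range for compound 4 is kept wide. On that basis compound 4 is estimated at 4000 nM, within 1200 nM to 15000 nM. The expected step is therefore a 4.0-fold higher number from compound 1 to compound 4 (0.61 log units; beyond the scatter), a modest weakening.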

Compound 4, half-maximal inhibitory concentration: 18100 nM
Compound 4: the middle estimate sits 4.5-fold (0.66 log units) below what was measured, and the stated range ends below it.
By their numbers in this assay, from the lowest: compound 1; then compound 3; then compound 4. At a limit, above all of these: compound 2.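

Compound 3 and compound 4 differ only at the ester, and that single change counts in this assay: a 6.4-fold higher number from compound 3 to compound 4 (0.81 log units; beyond the scatter). The methyl ester is therefore a poor stand-in for the free carboxylic acid at this chain end, and replacing pyrrolidin-1-yl with (carboxymethyl)amino costs far more, an 18-fold higher number from compound 1 to compound 4 (1.26 log units; beyond the scatter), than the ester step alone indicated. The step to compound 4 from the dipropylamino compound is only a bound and rests on a limit: an at least 2.7-fold lower number from compound 2 to compound 4 (0.44 log units; beyond the scatter), with the limit reading: the limit of > 50000 nM in this assay, at which 1 of the 4 values shown sits.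

The compounds shown do not separate the effect of the pyrrolidine ring from that of the amine substituents, which a piperidine, a morpholine or a diethylamino group on the same propyl chain could address. As far as these compounds go, whether the loss with the carboxylic acid persists in a primary amide or an ethyl ester also remains open.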